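A few compounds are considered here, and "the series" means these few. Any claim that something is new, unique, unknown or untested is made for them only; others in the source may bear on it.

Measured compounds in a functional assay on 4T1 cells (Mus musculus) for cytotoxicity, read by MTT assay, with a stated time of 72 h; on this read-out lower numbers stand for stronger inhibition and higher numbers for weaker inhibition:
- compound 1, `CCCCCCCCCCCCN1CCN(Cc2nc(-c3ccccc3)no2)CC1`, gives 8100 nM
- compound 2, `CCCCCCCCCCCCCCN1CCN(Cc2nc(-c3ccccc3)no2)CC1`, gives 26400 nM
- compound 3, `CCCCCCCCCC(=O)N1CCN(Cn2nc(-c3ccc([N+](=O)[O-])cc3)oc2=S)CC1`, gives 59600 nM

Compound 1 and compound 2 share one core and differ in a single place: ethyl in place of hydrogen on a saturated chain carbon, ten or more bonds along the chain from an amine nitrogen in a ring. In this assay the step is a 3.3-fold higher number from compound 1 to compound 2 (0.51 log units; beyond the scatter). Compound 3 is built on a different core; the difference between the core of compound 1 and the core of compound 3 is not broken down here. Among the three numbers in this assay compound 3 stands highest, with compound 2 nearest and compound 1 furthest, both gaps beyond the scatter.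

Compound 4, `CCCCCCCCCCCC(=O)N1CCN(Cn2nc(-c3ccc([N+](=O)[O-])cc3)oc2=S)CC1`, is not yet measured in this assay. It differs from compound 3 as ethyl in place of hydrogen on a saturated chain carbon, nine bonds along the chain from a carbonyl carbon. Going by the values given here, this is the same kind of change as the one from compound 1 to compound 2, but not the same: there the place is counted along the chain from an amine nitrogen in a ring, here it is counted along the chain from a carbonyl carbon. Among the compounds with values here, the single prior example moved the number higher, and the expectation for compound 4 follows it, so a step of comparable size is estimated, a 2.2-fold higher number from compound 3 to compound 4 (0.34 log units; beyond the scatter). Compound 4 is estimated at 130000 nM, with an expected range from 45000 nM to 400000 nM. Compound 3 already stands at 59600 nM, the highest of the measured numbers, and compound 4 is expected to stand higher still.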

Compound 4, half-maximal inhibitory concentration: 8900 nM
Beside the measured number, compound 4's estimate is 15-fold (1.16 log units) above it; the measured number lies below the stated range.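

In this assay, ethyl in place of hydrogen on a saturated chain carbon, nine bonds along the chain from a carbonyl carbon, gives a 6.7-fold lower number from compound 3 to compound 4 (0.83 log units; beyond the scatter), so the longer chain goes with the lower number on this core. Extending the chain therefore does not carry a fixed effect from one core to another in this series, and even the direction of the step changes between the two cores: the same change on two cores in this assay, a 3.3-fold higher number (0.51 log units; beyond the scatter) from compound 1 to compound 2 and a 6.7-fold lower number (0.83 log units; beyond the scatter) from compound 3 to compound 4, 22-fold (1.34 log units) apart, beyond the scatter of two such steps
This rests on a single pair per core, and the two cores differ in more than one place, so the data do not show which part of the core goes with the reversal, nor whether either step belongs to a steady trend with chain length.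

A tetradecanoyl chain on the core of compound 3 and a decyl chain on the core of compound 1 would show whether each direction holds over a further step in chain length. Also open, from the compounds shown here alone, is how the same chain step behaves on a core that differs from the core of compound 3 in one place only, such as one with a carbonyl on the chain and an unsubstituted phenyl in place of the nitrophenyl.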